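The compounds below may be only part of what the source reports. "The series", "measured", "known", "first", "only" and "open" are said of these compounds alone.

Compound 1 `Nc1ccccc1NC(=O)c1ccc(CSC(=S)N2CCN(c3ccc(Cl)cc3)CC2)cc1` stands lowest of the three measured compounds in a functional assay on MGC-803 cells (Homo sapiens) for antiproliferative activity, read by CCK-8 assay, with a stated time of 72 h, tested at 8 uM (on this read-out higher numbers stand for a stronger effect at the one concentration tested and lower numbers for a weaker effect), where compound 1 gives 17.2%. Compound 2 `CN(Cc1cccnc1)C(=S)SCc1ccc(C(=O)Nc2ccccc2N)cc1` gives 85.5% and compound 3 `Nc1ccccc1NC(=O)c1ccc(CSC(=S)N2CCCc3ccccc32)cc1` gives 87.5%, both far beyond the scatter above compound 1. For the measured compounds named here, the one measured step, a number 2 percentage points higher from compound 2 to compound 3 (within the scatter), exchanges the amine on the thiocarbonyl carbon and does not touch the aryl ring that carries the change in question, so no measured step bears directly on the move from compound 1 to compound 4.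

Compound 4 `COc1ccc(N2CCN(C(=S)SCc3ccc(C(=O)Nc4ccccc4N)cc3)CC2)cc1` differs from compound 1 by methoxy in place of chloro on an aromatic carbon, on the aryl ring attached to the piperazine. Going by the values given here, with no measured step on this position, the expectation rests on compound 1 alone: a low starting point, and no evidence for either direction. The step is therefore expected to be a number 12.8 percentage points higher from compound 1 to compound 4 (beyond the scatter), not clearly beyond the scatter, with a wide range. For compound 4 the estimate in this assay is 30%, between 5% and 75%.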

Compound 4, a percentage reported as inhibition, at one concentration (the size of the read-out at that concentration, not a potency): 22.9%
Compound 4: middle estimate off by 7.1 percentage points, on the high side, within the range that was stated.
By their numbers in this assay, from the lowest: compounds 1 and 4 (each within the scatter of the next); then compounds 2 and 3 (each within the scatter of the next).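

In this assay, the step for methoxy in place of chloro on an aromatic carbon, para to a large group, reads a number 5.7 percentage points higher from compound 1 to compound 4 (within the scatter). At this position, then, 4-methoxyphenyl and 4-chlorophenyl cannot be told apart at the one concentration tested, even though the exchange adds a hydrogen-bond acceptor, and this change alone does not lift the low read-out of compound 1. No available evidence speaks to why the two groups read alike.

As far as these compounds go, whether a different group on this ring, such as an amine or a carboxylic acid, would shift the read-out remains open. Also open, from the compounds shown here alone, is whether the two compounds would separate in a full concentration series, which a single-concentration read-out cannot show.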